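The compounds below may be only part of what the source reports. "The series", "measured", "known", "first", "only" and "open" are said of these compounds alone.

Compound 1 `CCCCCCCCCCCSC(=S)C1=C(Nc2ccc(Cl)cc2)CC(C)(C)CC1=O` is the starting point. In a functional assay on cells (blood, Homo sapiens) for inhibition, read by chemiluminescence, with a stated time of 30 min (a higher number here means a weaker inhibitor, a lower number a stronger inhibitor), compound 1 gives only a limit, > 100 ug/mL. Compound 2 `CC1(C)CC(=O)C(C(=S)SCc2ccccc2)=C(Nc2ccc(Cl)cc2)C1` differs from compound 1 by phenyl in place of decyl on a saturated chain carbon bound to a sulfur. In this assay compound 2 likewise gives only a limit, > 100 ug/mL. The step is therefore a step that the two limits leave unreadable from compound 1 to compound 2. Compound 3 `CCCCCCCCCCCSC(=S)C1=C(Nc2ccc(Br)cc2)CC(C)(C)CC1=O` differs from compound 1 by bromo in place of chloro on an aromatic carbon, and this is how the two cores differ. In this assay compound 3 again gives only a limit, > 100 ug/mL. That step reads a step that the two limits leave unreadable from compound 1 to compound 3. Compound 4 `CC1(C)CC(=O)C(C(=S)SCc2ccccc2)=C(Nc2ccc(Br)cc2)C1`, not yet measured, differs from compound 3 by phenyl in place of decyl on a saturated chain carbon bound to a sulfur, the same change that separates compound 1 from compound 2. Because (the limit of > 100 ug/mL in this assay, at which 3 of the 3 values shown sit), the step expected is a step that the limit leaves unreadable from compound 3 to compound 4, a limit-to-limit step. Compound 4 is thus estimated at 150 ug/mL, with a range of 60 ug/mL to 400 ug/mL.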

Compound 4, half-maximal inhibitory concentration: > 100 ug/mL
Compound 4 was reported as a limit; the forecaster's own chance of this, stated with the estimate: 85%; the middle value lies beyond the limit too.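

In this assay compound 4 gives only a limit, > 100 ug/mL, so neither its step from compound 3 nor its step from compound 2 can be read. The compounds shown leave open how strongly any of them inhibits and whether either change alters inhibition.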